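Swapping chloro for bromo at one aromatic position

The compounds below may be only part of what the source reports. "The series", "measured", "known", "first", "only" and "open" are said of these compounds alone.

Going by the values given here, compound 1 `COC(=O)c1ccc(NCc2cncn2Cc2ccc(Cl)cc2)cc1-c1ccccc1` is the only compound here with a definite number in a toxicity assay on NIH3T3 cells (Mus musculus) for cytotoxicity, read by resazurin assay; a lower number here means that less compound is needed, a higher number that more compound is needed for the effect: compound 1 gives 25000 nM. Compound 2 `COc1ccc(NCc2cncn2Cc2ccc(-c3ccccc3)cc2N)cc1-c1ccccc1` reaches only a limit of the assay in this assay, > 1000 nM. Compound 3 `c1ccc(-c2ccc(Cn3cncc3CNc3ccc(-c4nc5ccccc5o4)c(-c4ccccc4)c3)cc2)cc1` likewise reaches only a limit in this assay, > 10000 nM. Compound 4 `COC(=O)c1ccc(NCc2cncn2Cc2ccc(Br)cc2)cc1-c1ccccc1` differs from compound 1 in one place: bromo in place of chloro on an aromatic carbon. Among the compounds with values here, no measured pair in this set shows what such a change does. Exchanging chloro for bromo is expected to shift this assay by no more than the usual scatter, so the expected step of no change at the digits printed from compound 1 to compound 4 (within the scatter) is essentially flat. Compound 4 is therefore estimated at 25000 nM, expected to lie within 10000 nM to 60000 nM.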

Compound 4, half-maximal effective concentration: > 10000 nM
Compound 4 ended at the assay's limit; the forecaster's own chance of this, stated with the estimate: 25%; the middle value does not contradict the limit.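

Going by these compounds alone, compound 4 gives only a limit in this assay, > 10000 nM, so no step from compound 1 to compound 4 can be read. On these data alone, whether bromo in place of chloro shifts this assay at all stays open.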